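A bromo for methyl swap in a weak pair

The compounds below may be only part of what the source reports. "The series", "measured", "known", "first", "only" and "open" are said of these compounds alone.

Compound 1 `O=C1/C(=C/c2ccccc2Cl)Cc2ccccc21` gives 152000 nM as its measured value
Compound 2 `Cc1ccccc1/C=C1\Cc2ccccc2C1=O` gives 208000 nM as its measured value

Among the compounds with values here, in a functional assay on L1210 cells (Mus musculus) for inhibition (a higher number here means a weaker inhibitor, a lower number a stronger inhibitor), compound 2 cannot be told apart from compound 1, the only other measured compound. Between them lies a 1.4-fold higher number from compound 1 to compound 2 (0.14 log units; within the scatter) (methyl in place of chloro on an aromatic carbon). Compound 3 `O=C1/C(=C/c2ccccc2Br)Cc2ccccc21` remains unmeasured. It carries bromo in place of methyl on an aromatic carbon, ortho to a large group. Within the data shown here, only one measured step bears on this change, and with a 1.4-fold higher number from compound 1 to compound 2 (0.14 log units; within the scatter) as the sole guide, no step beyond the scatter is expected in this assay here. The estimated change is a 1.2-fold lower number from compound 2 to compound 3 (0.09 log units; within the scatter) and is expected to stay within the scatter. For compound 3 the expected value is 170000 nM with an estimated range from 90000 nM to 320000 nM in this read-out.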

Compound 3, half-maximal inhibitory concentration: 64200 nM
The estimate for compound 3 lay 2.6-fold (0.42 log units) above the measured number; measured number below the stated range.
By their numbers in this assay, from the lowest: compound 3; then compounds 1 and 2 (each within the scatter of the next).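

In this assay, this position, ortho to a large group, now shows a change beyond the scatter, which the exchange of chloro and methyl had not shown: bromo in place of methyl gives a modest step (a 3.2-fold lower number from compound 2 to compound 3 (0.51 log units; beyond the scatter)), and bromo in place of chloro gives another (a 2.4-fold lower number from compound 1 to compound 3 (0.37 log units; beyond the scatter)). Compound 3 is therefore the strongest inhibitor of the three, while compound 1 and compound 2 remain within the scatter of each other, so here bromo stands apart from both chloro and methyl. Nothing available accounts for this difference.

The compounds shown leave open whether iodo, methoxy or an amine at this position would lower the number further. They also leave open whether bromo would give a similar step on another core.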